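Swapping the dithiocarbamate amine on a benzamide scaffold

The compounds below may be only part of what the source reports. "The series", "measured", "known", "first", "only" and "open" are said of these compounds alone.

Compound 1 `Nc1ccccc1NC(=O)c1ccc(CSC(=S)N2CCN(c3ccccc3)CC2)cc1`: 2860 nM
Compound 2 `Nc1ccccc1NC(=O)c1ccc(CSC(=S)N2CCc3ccccc32)cc1`: 3040 nM

Two compounds share a benzamide core carrying a dithiocarbamate on the benzylic side. In a functional assay on SMMC-7721 cells (Homo sapiens) for antiproliferative activity, read by CCK-8 assay, with a stated time of 72 h (a lower number here means a stronger inhibitor, a higher number a weaker inhibitor), compound 1 gives 2860 nM, and compound 2 gives 3040 nM. Compound 2 has the higher number of the two, but its gap to compound 1 lies within the scatter, so the two compounds cannot be told apart on these data.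

Compound 3 `CCN(Cc1ccncc1)C(=S)SCc1ccc(C(=O)Nc2ccccc2N)cc1` has not yet been measured. It differs from compound 2 in one place: ethyl((pyridin-4-yl)methyl)amino in place of 2,3-dihydro-1H-indol-1-yl on a thiocarbonyl carbon. Among the measured compounds shown here, no measured pair shows this change, so there is nothing to read a direction from. Since compound 1 and compound 2 with two different amines give the same number, a step no larger than the scatter is expected in this assay, with a 1.2-fold higher number from compound 2 to compound 3 (0.06 log units; within the scatter) as the expected change. Compound 3 is therefore estimated at 3500 nM, with a range from 1500 nM to 9000 nM.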

Compound 3, half-maximal inhibitory concentration: 1210 nM
The estimate for compound 3 lay 2.9-fold (0.46 log units) above the measured number; the whole stated range lies above it.
By their numbers in this assay, from the lowest: compound 3; then compounds 1 and 2 (each within the scatter of the next).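

In this assay, the amine on the thiocarbonyl carbon proves able to move the number: ethyl((pyridin-4-yl)methyl)amino in place of 2,3-dihydro-1H-indol-1-yl gives a 2.5-fold lower number from compound 2 to compound 3 (0.40 log units; beyond the scatter). The pair of compound 1 and compound 2 did not show this, as their two amines gave values within the scatter of each other, so not every change of amine here is silent, though this step is modest and rests on one pair. Nothing available bears on why the number drops with this change.

As far as these compounds go, this one step changes the ethyl group and the pyridin-4-yl ring together, so their separate shares remain open. Also open, from the compounds shown here alone, is how a morpholine, a piperidine or a simple dimethylamino group would compare on the thiocarbonyl carbon.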